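This account rests on a few compounds, and the source may have more. Where it says the series, first, only, none or still open, it means among the compounds named here.

Measured in a functional assay on the whole organism with Rattus norvegicus as the target; a higher number here means that more compound is needed for the effect, a lower number that less compound is needed:
Compound 1 `C/C=C\C=C\[C@](C)(O)C/C=C/[C@H]1[C@H](O)CC(=O)[C@@H]1CC/C=C\CCC(=O)OC`: 0.306 mg/kg
Compound 2 `COC(=O)CC/C=C\CC[C@H]1C(=O)C[C@@H](O)[C@@H]1/C=C/C[C@@](C)(O)/C=C/C(C)=C(C)C`: > 3.16 mg/kg (a limit of the assay, not a number)
Compound 3 `C/C=C/C=C/[C@](C)(O)C/C=C/[C@H]1[C@H](O)CC(=O)[C@@H]1CC/C=C\CCC(=O)OC`: 0.25 mg/kg

In this assay, compound 3 stands level with compound 1 within the scatter, a 1.2-fold lower number from compound 1 to compound 3 (0.09 log units; within the scatter), and the pair shows (the fact that compounds 1 and 3 differ only in the configuration as drawn). Against compound 2 the gap is clear: an at least 12-fold lower number from compound 2 to compound 3 (1.10 log units; beyond the scatter). That gap is open-ended, resting on (the limit of > 3.16 mg/kg in this assay, at which 1 of the 3 values shown sits).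

Compound 4 `C=C/C=C(\C)[C@](C)(O)C/C=C/[C@H]1[C@H](O)CC(=O)[C@@H]1CC/C=C\CCC(=O)OC` is the next step from compound 3: 1-methylbuta-1,3-dien-1-yl in place of penta-1,3-dien-1-yl on a saturated chain carbon bound to an oxygen on a saturated carbon and two saturated chain carbons. In it, 1-methylbuta-1,3-dien-1-yl stands in place of penta-1,3-dien-1-yl on a saturated chain carbon bound to an oxygen on a saturated carbon and two saturated chain carbons.

Among the compounds with values here, two measured steps bear on this. The geometry change in a 1.2-fold lower number from compound 1 to compound 3 (0.09 log units; within the scatter) stayed within the scatter, but it moved no methyl group. The closer precedent is an at least 10-fold higher number from compound 1 to compound 2 (1.01 log units; beyond the scatter), where 1,2-dimethylprop-1-en-1-yl replaced prop-1-en-1-yl. That step also altered the methyl pattern of the unsaturated chain, though not at the same carbon or to the same extent. A higher number is therefore expected in this assay, but a smaller rise than in that precedent. The estimated step is a 3.2-fold higher number from compound 3 to compound 4 (0.51 log units; beyond the scatter). For compound 4 the expected value is 0.8 mg/kg, with an estimated range of 0.2 mg/kg to 3.2 mg/kg.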

Compound 4, dose for half-maximal effect: > 3.16 mg/kg
Compound 4: a limit, no number (the forecaster's own chance of this, stated with the estimate: 20%); middle value at least 3.9-fold (0.59 log units) away from the limit.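

In this assay, 1-methylbuta-1,3-dien-1-yl and penta-1,3-dien-1-yl both count 5 heavy atoms and 2 double bonds, yet joining those atoms differently, on a saturated chain carbon bound to an oxygen on a saturated carbon and two saturated chain carbons, gives an at least 12-fold higher number from compound 3 to compound 4 (1.10 log units; beyond the scatter). The same change starting from the other drawn double-bond geometry gives an at least 10-fold higher number from compound 1 to compound 4 (1.01 log units; beyond the scatter), whereas the geometry change alone stayed within the scatter, as a 1.2-fold lower number from compound 1 to compound 3 (0.09 log units; within the scatter) shows, so at this position the way the chain is branched counts for far more in these compounds than that double-bond geometry. The value of compound 4 is a limit, as is that of compound 2, so the step between those two compounds cannot be read: the limit of > 3.16 mg/kg in this assay, at which 2 of the 4 values shown sit.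

How far compound 4 lies beyond its limit remains unknown, and both large steps are open-ended for the same reason. Also open, going by these compounds, is what a different group in this place, such as a phenyl ring or a shorter unbranched chain like prop-1-en-1-yl, would do in this assay.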